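This account rests on a few compounds, and the source may have more. Where it says the series, first, only, none or still open, it means among the compounds named here.

Measured compounds:
compound 1, `O=C(O)c1cccc(Cc2c(-c3cccc(Cl)c3)nn3cc(Cl)ccc23)n1`, 480 nM
compound 2, `O=C(O)c1cccc(Cc2c(-c3ccsc3)nn3cc(Cl)ccc23)n1`, 110 nM
compound 3, `O=C(O)c1cccc(Cc2c(-c3ccco3)nn3cc(Cl)ccc23)n1`, 1200 nM

All three were measured in a functional assay on cells for antagonist activity at prostaglandin E2 receptor EP1 subtype (Rattus norvegicus), read by fluorescence and calcium flux, with a stated time of 60 s; a higher number here means a weaker inhibitor, a lower number a stronger inhibitor. Compound 3 gives the highest number of the three: it stands a 2.5-fold higher number from compound 1 to compound 3 (0.40 log units; beyond the scatter) and an 11-fold higher number from compound 2 to compound 3 (1.04 log units; beyond the scatter). These two steps are the ones that bear on the change now considered, since both end at compound 3 and both show that the group at this position of the shared core moves the number by a modest to a large amount.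

Compound 4, `CC(C)Cc1nn2cc(Cl)ccc2c1Cc1cccc(C(=O)O)n1`, differs from compound 3 in one place: isobutyl in place of furan-2-yl on an aromatic carbon. Among the measured compounds shown here, no measured step exchanges an aromatic ring for a chain at this position, so the two steps into compound 3 only show how far the number can move here, not the direction for this change. Compound 4 is therefore expected to lie near compound 3, with the step of a 1.3-fold higher number from compound 3 to compound 4 (0.10 log units; within the scatter) carrying wide uncertainty in both directions. The estimate for compound 4 is 1500 nM, with a range from 400 nM to 6000 nM.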

Compound 4, half-maximal inhibitory concentration: 200 nM
Compound 4: the middle estimate sits 7.5-fold (0.88 log units) above what was measured; measured number below the stated range.
By their numbers in this assay, from the lowest: compounds 2 and 4 (each within the scatter of the next); then compound 1; then compound 3.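

In this assay, isobutyl in place of furan-2-yl gives a 6.0-fold lower number from compound 3 to compound 4 (0.78 log units; beyond the scatter) and isobutyl in place of 3-chlorophenyl gives a 2.4-fold lower number from compound 1 to compound 4 (0.38 log units; beyond the scatter) so an aromatic ring is not required at this position for a lower number than these two rings give. Isobutyl in place of thiophen-3-yl gives a 1.8-fold higher number from compound 2 to compound 4 (0.26 log units; within the scatter) so this chain and thiophen-3-yl cannot be told apart here, and the change from ring to chain has no single direction across the compounds shown. No evidence at hand bears on these steps, and what lies behind them stays unexplained.

With isobutyl the only chain among these compounds, they leave open how a longer chain, a cyclohexyl ring or an amine at this position would move the number. From the compounds shown here alone, whether these steps hold with a group other than chlorine on the shared core also stays open.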